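Clearance of compound 3 and the step to compound 4

A few compounds are considered here, and "the series" means these few. Any claim that something is new, unique, unknown or untested is made for them only; others in the source may bear on it.

Measured in an ADME assay (Rattus norvegicus, strain Han-wistar) for pharmacokinetics, at a dose of 1.5 umol/kg by the intravenous route; a higher number here means faster removal of the compound, a lower number slower removal:
compound 1 `CNC(=O)CN1CCC(c2cc3c(-c4ccc(=O)n(C(C)C)c4)ccnc3[nH]2)CC1`: 89 mL/min/kg
compound 2 `CC(C)n1cc(-c2ccnc3[nH]c(C4CCN(CC(=O)N5CCCC5)CC4)cc23)ccc1=O`: 91 mL/min/kg
compound 3 `COc1cc(F)ccc1-c1ccnc2[nH]c(C3CCN(CC(=O)N(C)C)CC3)cc12`: 51 mL/min/kg

In this assay, compound 3 at 51 mL/min/kg stands within the usual scatter of both compound 1 and compound 2. Compound 4 `CC(C)n1cc(-c2ccnc3[nH]c(C4CCN(CC(=O)N(C)C)CC4)cc23)cnc1=O` keeps the rest of compound 3, but on an aromatic carbon opposite the ring nitrogen the 4-fluoro-2-methoxyphenyl leaves: a group of 10 heavy atoms (7 carbon, 2 nitrogen, 1 oxygen; one six-membered aromatic ring with 2 hetero atoms) in place of a group of 9 heavy atoms (7 carbon, 1 oxygen, 1 fluorine; one six-membered aromatic ring of carbon only), on an aromatic carbon. Going by the values given here, no measured step covers this change. Among the compounds with values here, the one measured step, a 1.0-fold higher number from compound 1 to compound 2 (0.01 log units; within the scatter), lies within the scatter and sits at a different place. However, compound 1 at 89 mL/min/kg and compound 2 at 91 mL/min/kg carry a resembling ring group at the changed place, so a modest rise is expected, still within the scatter. The expected step is a 1.4-fold higher number from compound 3 to compound 4 (0.14 log units; within the scatter). For compound 4 the estimated value is 70 mL/min/kg, with an expected range from 42 mL/min/kg to 110 mL/min/kg.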

Compound 4, clearance: 72 mL/min/kg
Beside the measured number, compound 4's estimate is 1.0-fold (0.01 log units) below it; measured number inside the range.
By their numbers in this assay, from the lowest: compounds 3, 4, 1 and 2 (each within the scatter of the next).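

In this assay, placing the ring with 2 hetero atoms on the aromatic carbon opposite the ring nitrogen, where the 4-fluoro-2-methoxyphenyl stood, gives a 1.4-fold higher number from compound 3 to compound 4 (0.15 log units; within the scatter). Going by these compounds alone, this is the first measured exchange at this position, and it shows that a carbon-only aromatic ring and this ring with 2 hetero atoms read alike here, within the scatter of each other. No measurement at hand accounts for this result.

The compounds shown leave open whether a plain phenyl or a ring carrying a carboxylic acid or an amine at this position would also stay within the scatter. They also leave open how the fluoro and methoxy groups each contribute on their own.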